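Fluoro for methoxy at the para position of a diaryl imidazole

This account rests on a few compounds, and the source may have more. Where it says the series, first, only, none or still open, it means among the compounds named here.

Compounds measured so far:
compound 1 `COc1ccc(-c2nc(-c3ccccc3)c(-c3ccc4c(c3)NC(=O)CO4)[nH]2)cc1`: 101%
compound 2 `O=C1COc2ccc(-c3nn(-c4ccc(Cl)cc4)cc3-c3ccccc3)cc2N1`: 84.4%

In a functional assay on A549 cells (Homo sapiens) for cytotoxicity, read by colorimetric assay and MTT assay, with a stated time of 3 days, tested at 1 uM (a higher number here means a weaker effect of the compound at the concentration tested, a lower number a stronger effect), compound 1 gives 101%, the highest of the two numbers; compound 2 gives 84.4%, a gap beyond the scatter. Compound 3 `O=C1COc2ccc(-c3[nH]c(-c4ccc(F)cc4)nc3-c3ccccc3)cc2N1` differs from compound 1 in one place: fluoro in place of methoxy on an aromatic carbon. Going by the values given here, no step between measured compounds tells how this change plays out. The expectation for a number 6 percentage points lower from compound 1 to compound 3 (within the scatter) is a small step downward, if any, likely within the scatter. Compound 3 is therefore estimated at 95%, with a range from 80% to 108%.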

Compound 3, a percentage reported as activity, at one concentration (the size of the read-out at that concentration, not a potency): 97.1%
The estimate for compound 3 lay 2.1 percentage points below the measured number, within the range that was stated.
By their numbers in this assay, from the lowest: compound 2; then compounds 3 and 1 (each within the scatter of the next).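

Fluoro in place of methoxy on this aromatic carbon gives, in this assay, a number 3.9 percentage points lower from compound 1 to compound 3 (within the scatter). Going by these compounds alone, this is the first single-place comparison here, and it shows that 4-methoxyphenyl and 4-fluorophenyl cannot be told apart at this position in this read-out. Nothing measured alongside these compounds offers an explanation for this result.

From the compounds shown here alone, whether an amine, a carboxylic acid or a longer chain such as butoxy at this position would move the number beyond the scatter remains open. Going by these compounds, whether the same exchange would behave alike elsewhere on the core of compound 1 also remains open.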